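The source may report more compounds than this note shows. Statements on the series, on what has been measured and on what is new or still open speak of the compounds shown alone.

In a functional assay on HUVEC cells (Homo sapiens) for antiproliferative activity, read by MTT assay, with a stated time of 48 h (on this read-out lower numbers stand for stronger inhibition and higher numbers for weaker inhibition), compound 3 `COc1ccc(-c2cc3cc(OC)ccc3nc2Nc2ccc(NC(=O)CN(C)C)cc2)cc1` gives 22200 nM, which is the second highest of the three numbers recorded. Its nearest neighbour is compound 2 `COc1ccc(-c2cc3ccc(OC)cc3nc2Nc2ccc(NC(=O)CN3CCCCC3)cc2)cc1`, which in this assay gives 23500 nM, and the furthest is compound 1 `CCN(CC)CC(=O)Nc1ccc(Nc2nc3cc(OC)ccc3cc2-c2ccc(OC)cc2)cc1`, which gives 14000 nM; both gaps to compound 3 lie within the scatter, so the three compounds cannot be told apart on this read-out.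

Compound 4 `COc1ccc(-c2cc3cc(OC)ccc3nc2Nc2ccc(NC(=O)CN3CCCCC3)cc2)cc1` is the next compound in the set. It differs from compound 3 in one place: piperidin-1-yl in place of dimethylamino on a saturated chain carbon bound to a carbonyl carbon. Within the data shown here, one measured step bears on this change, the one in which a ring amine replaces an open-chain amine at the same position, a 1.7-fold higher number from compound 1 to compound 2 (0.22 log units; within the scatter). That step did not move the number beyond the scatter, and compound 2, which already carries the piperidin-1-yl group, sits within the scatter of compound 3. The account therefore expects no shift beyond the scatter in this assay, at most a drift toward a slightly higher number in line with a 1.7-fold higher number from compound 1 to compound 2 (0.22 log units; within the scatter).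

On this basis the estimated step is a 1.1-fold higher number from compound 3 to compound 4 (0.05 log units; within the scatter), and compound 4 is expected to give about 25000 nM in this assay, most likely between 12000 nM and 50000 nM.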

Compound 4, half-maximal inhibitory concentration: > 50000 nM
Compound 4 ended at the assay's limit; the forecaster's own chance of this, stated with the estimate: 10%; middle value at least 2.0-fold (0.30 log units) from the limit.
By their numbers in this assay, from the lowest: compounds 1, 3 and 2 (each within the scatter of the next). At a limit, above all of these: compound 4.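

In this assay, the change from dimethylamino to piperidin-1-yl on a saturated chain carbon bound to a carbonyl carbon is the first shown at this position to pass the scatter, with an at least 2.2-fold higher number from compound 3 to compound 4 (0.35 log units; beyond the scatter), whereas the earlier change to the same group, a 1.7-fold higher number from compound 1 to compound 2 (0.22 log units; within the scatter), stayed within it. The piperidin-1-yl group therefore does not read alike on the two cores shown: it is shared with compound 4, yet on its own core compound 2 gives 23500 nM. The true size of the new step remains unknown, as compound 4 stands at a limit of the assay and not at a number: the limit of > 50000 nM in this assay, at which 1 of the 4 values shown sits.

As far as these compounds go, it remains open how far past that limit compound 4 lies, and whether the step belongs to the piperidin-1-yl group alone or to that group together with the core of compound 3. The compounds shown also do not tell how a pyrrolidine ring or a morpholine ring in the same place on the core of compound 3 would read in this assay.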